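Chloro Added to the Amide Aryl Ring of Compound 3

This account rests on a few compounds, and the source may have more. Where it says the series, first, only, none or still open, it means among the compounds named here.

Measured compounds:
compound 1, `O=C(Nc1cccc(-n2cc(-c3ccncc3)c(-c3ccc(Cl)c(O)c3)n2)c1)Nc1cccc(C(F)(F)F)c1`: 1900 nM
compound 2, `COc1cc(-c2nn(-c3cccc(NC(=O)Nc4cc(C(F)(F)F)cc(C(F)(F)F)c4)c3)cc2-c2ccncc2)ccc1Cl`: 1090 nM
compound 3, `COc1cc(-c2nn(-c3cccc(NC(=O)c4cccc(C(F)(F)F)c4)c3)cc2-c2ccncc2)ccc1Cl`: 1560 nM

In a functional assay on NCI-H23 cells (Homo sapiens) for inhibition, read by sulforhodamine B assay, with a stated time of 48 h (a higher number here means a weaker inhibitor of growth, a lower number a stronger inhibitor of growth), compound 3 gives 1560 nM and stands second highest of the three numbers shown. Its nearest neighbour is compound 1 with 1900 nM, a gap within the scatter; the furthest is compound 2 with 1090 nM, also within the scatter. For the measured compounds named here, the three measured compounds differ from one another in more than one place, so no single step between them can be read from these numbers.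

Compound 4 is `COc1cc(-c2nn(-c3cccc(NC(=O)c4ccc(Cl)c(C(F)(F)F)c4)c3)cc2-c2ccncc2)ccc1Cl`, and it differs from compound 3 in one place only: chloro in place of hydrogen on an aromatic carbon. A trifluoromethyl group already sits on that ring in compound 3, and the new chlorine joins it. Going by the values given here, with no comparable step among the measured compounds to lean on, the expected change is small: the author expects the step of a 1.2-fold lower number from compound 3 to compound 4 (0.08 log units; within the scatter) in this assay to fall within the scatter rather than beyond it. Compound 4 is therefore estimated at 1300 nM, within a range from 500 nM to 3500 nM.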

Compound 4, concentration for 50% growth inhibition: 5390 nM
Compound 4: the middle estimate sits 4.1-fold (0.62 log units) below what was measured; measured number outside the range, above it.
By their numbers in this assay, from the lowest: compounds 2, 3 and 1 (each within the scatter of the next); then compound 4.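

In this assay, the only step that can be read among these compounds is a 3.5-fold higher number from compound 3 to compound 4 (0.54 log units; beyond the scatter), and it lies beyond the scatter. It shows that this aromatic carbon, ortho to a trifluoromethyl group and para to a large group, is not indifferent to substitution: chloro in place of hydrogen here goes with weaker inhibition of growth, at least on this one background. No measurement shown bears on what lies behind this rise.

As far as these compounds go, whether the loss is specific to chloro remains open, as this single step cannot say what fluoro, methyl or an amine at the same carbon would give. Nor can it say whether chloro at this place would have the same effect on compound 1 or compound 2, which differ from compound 3 in more than one place.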